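The source may report more compounds than this note shows. Statements on the series, on what has been measured and on what is new or still open speak of the compounds shown alone.

Measured so far in a functional assay on MCF7 cells (Homo sapiens) for inhibition, read by fluorescence, with a stated time of 72 h; a higher number here means a weaker inhibitor of growth, a lower number a stronger inhibitor of growth
- Compound 1 `CCCCCCn1cnc2c(Nc3ccc(O)cc3)nc(N[C@H]3CC[C@H](N)CC3)nc21` gives 3500 nM
- Compound 2 `CC(C)CCn1cnc2c(Nc3cccc(Cl)c3)nc(N[C@H]3CC[C@H](N)CC3)nc21` gives 2100 nM

Compound 2 and compound 1 lie within the usual scatter of each other, so these numbers cannot separate them. Compound 3 `CC(C)CCn1cnc2c(Nc3ccc(O)cc3)nc(N[C@H]3CC[C@H](N)CC3)nc21` differs from compound 2 in one place (4-hydroxyphenyl in place of 3-chlorophenyl on a nitrogen on an aromatic ring) with 4-hydroxyphenyl in place of 3-chlorophenyl on a nitrogen on an aromatic ring. Compound 1 at 3500 nM already carries 4-hydroxyphenyl there, so no shift beyond the scatter is expected in this assay for this change. The estimated step of a 1.4-fold higher number from compound 2 to compound 3 (0.15 log units; within the scatter) stays within that scatter. The expected value for compound 3 is 3000 nM with an estimated range from 1300 nM to 7000 nM.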

Compound 3, concentration for 50% growth inhibition: 3100 nM
Compound 3: the middle estimate sits 1.0-fold (0.01 log units) below what was measured; measured number inside the range.
By their numbers in this assay, from the lowest: compounds 2, 3 and 1 (each within the scatter of the next).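

In this assay the exchange of 3-chlorophenyl for 4-hydroxyphenyl on a nitrogen on an aromatic ring gives a 1.5-fold higher number from compound 2 to compound 3 (0.17 log units; within the scatter) and so leaves the growth inhibition unchanged as far as these numbers can tell. Isopropyl in place of butyl on a saturated chain carbon, two bonds along the chain from an aromatic nitrogen, gives a 1.1-fold lower number from compound 1 to compound 3 (0.05 log units; within the scatter) and likewise stays inside the noise, so neither place has yet shown a real shift. Nothing available explains this flat result. Still open, from the compounds shown here alone, is whether a pyridine in place of the 4-hydroxyphenyl, or a methyl in place of the chain, would move the number beyond the scatter.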